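The source may report more compounds than this note shows. Statements on the series, on what has been measured and on what is new or still open speak of the compounds shown alone.

Measured compounds:

- compound 1, `Cc1ccc(COc2ccc(-c3cc(CN4CCN(Cc5ccc(C(F)(F)F)cc5)CC4)no3)cc2)cc1`: 1200 nM
- compound 2, `FC(F)(F)c1ccc(CN2CCN(Cc3cc(-c4ccc(OCc5cccc(Cl)c5)cc4)on3)CC2)cc1`: 1400 nM
- compound 3, `Fc1ccc(COc2ccc(-c3cc(CN4CCN(Cc5ccc(C(F)(F)F)cc5)CC4)no3)cc2)cc1`: 7900 nM

In a functional assay on MCF7 cells (Homo sapiens) for antiproliferative activity, read by sulforhodamine B assay, with a stated time of 72 h (on this read-out lower numbers stand for stronger inhibition and higher numbers for weaker inhibition), compound 1 gives 1200 nM, the lowest number of the three; compound 2 sits close by, with a 1.2-fold higher number from compound 1 to compound 2 (0.07 log units; within the scatter), while compound 3 is clearly further off, with a 6.6-fold higher number from compound 1 to compound 3 (0.82 log units; beyond the scatter). Compound 4, `COc1cccc(COc2ccc(-c3cc(CN4CCN(Cc5ccc(C(F)(F)F)cc5)CC4)no3)cc2)c1`, has not yet been measured. It differs from compound 1 in one place: 3-methoxyphenyl in place of 4-methylphenyl on a saturated chain carbon bound to an oxygen on an aromatic ring.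

Going by the values given here, two measured steps bear on this change, since both swap the group on the same saturated chain carbon bound to an oxygen on an aromatic ring. Going to 3-chlorophenyl gave a 1.2-fold higher number from compound 1 to compound 2 (0.07 log units; within the scatter), a step within the scatter, whereas going to 4-fluorophenyl gave a 6.6-fold higher number from compound 1 to compound 3 (0.82 log units; beyond the scatter), and compound 2 to compound 3 gave a 5.6-fold higher number from compound 2 to compound 3 (0.75 log units; beyond the scatter). A group on that chain carbon can therefore be swapped with little change or with a modest loss, and nothing measured here separates the two outcomes for 3-methoxyphenyl. The expectation for compound 4 is a small step, a 1.7-fold higher number from compound 1 to compound 4 (0.22 log units; within the scatter), toward a somewhat higher number. Compound 4 is estimated at 2000 nM, with a range from 800 nM to 5000 nM.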

Compound 4, half-maximal inhibitory concentration: 2000 nM
For compound 4 middle estimate and measured number coincide at the digits printed; the measured number falls inside the stated range.
By their numbers in this assay, from the lowest: compounds 1, 2 and 4 (each within the scatter of the next); then compound 3.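

In this assay the 3-methoxyphenyl group on this saturated chain carbon stays within the scatter of 4-methylphenyl (a 1.7-fold higher number from compound 1 to compound 4 (0.22 log units; within the scatter)) and of 3-chlorophenyl (a 1.4-fold higher number from compound 2 to compound 4 (0.15 log units; within the scatter)), so a group bringing one hydrogen-bond acceptor fits the same level as these two. Compound 3 remains the exception to that level, now set apart from a third compound (a 4.0-fold lower number from compound 3 to compound 4 (0.60 log units; beyond the scatter)), which makes its 4-fluorophenyl group the odd one among the four rather than a sign that any swap here costs activity. Nothing measured on these compounds accounts for that exception.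

On these data alone, it remains open whether the gap at compound 3 follows from the fluoro group itself or from where a group sits on the ring. Also open, as far as these compounds go, is how an amine or a carboxylic acid on this ring would behave.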